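Bromo for cyano at the weak end of the series

A few compounds are considered here, and "the series" means these few. Any claim that something is new, unique, unknown or untested is made for them only; others in the source may bear on it.

Three compounds are measured in an assay on isolated protein for displacement of a labelled ligand from metabotropic glutamate receptor 5 (Rattus norvegicus); on this read-out lower numbers stand for stronger inhibition and higher numbers for weaker inhibition. Compound 1 `CC1(C)CC(=O)c2cc(C#N)c(SCc3ccccc3)nc2C1` gives 57000 nM and compound 2 `CC1(C)CC(=O)c2cc(C#N)c(NC3CCCC3)nc2C1` gives 49000 nM; these two numbers lie within the scatter of each other. Compound 3 `CC1(C)CCc2nc(C#Cc3ccccc3)ccc2C1=O` gives 23 nM in this assay, a far lower number than either. Compound 2 therefore stands second highest of the three, close to compound 1 and far from compound 3. Compound 4 `CC1(C)CC(=O)c2cc(Br)c(NC3CCCC3)nc2C1` differs from compound 2 in one place: bromo in place of cyano on an aromatic carbon. Among the compounds with values here, no measured pair shows this exchange, so its effect is unknown here. The expectation is a step no larger than the scatter, in either direction. Compound 4 is thus expected at about 50000 nM, with a range from 15000 nM to 150000 nM. This corresponds to an expected step of a 1.0-fold higher number from compound 2 to compound 4 (0.01 log units; within the scatter).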

Compound 4, half-maximal inhibitory concentration: 29000 nM
For compound 4 the middle estimate is 1.7-fold (0.24 log units) above the measured one; low and high end bracket the measured number.
By their numbers in this assay, from the lowest: compound 3; then compounds 4, 2 and 1 (each within the scatter of the next).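

In this assay bromo in place of cyano on the aromatic carbon ortho to a cyclopentylamino group gives a 1.7-fold lower number from compound 2 to compound 4 (0.23 log units; within the scatter) and so the two groups cannot be told apart at this position. Within the data shown here, this is the first pair that differs in one place, and the nitrile is not needed here to keep the reading of compound 2. No measured property bears on this result.

Going by these compounds, whether an amide, a carboxylic acid or a methyl at this position would read differently stays open. So does whether the same exchange reads alike with the other substituent of compound 1 in place of the cyclopentylamino group.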